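A few compounds are considered here, and "the series" means these few. Any claim that something is new, unique, unknown or untested is made for them only; others in the source may bear on it.

Measured so far in a physicochemical assay for solubility, at pH 7.4; on this read-out lower numbers stand for lower solubility and higher numbers for higher solubility:
- Compound 1 `C=CC(=O)Nc1ccccc1Cn1c(-c2nc(-c3cnn(C4CCN(C)CC4)c3)cnc2N)nc2ccccc21`: 35000 nM
- Compound 2 `C=CC(=O)Nc1cccc(-n2c(-c3nc(-c4cnn(C)c4)cnc3N)nc3ccccc32)c1`: < 10000 nM

Compound 2 has no exact number on this read-out. Its entry of < 10000 nM is a limit of the assay, so its true position is not known.

The next structure is compound 3 `C=CC(=O)Nc1cccc(-n2c(-c3nc(-c4cnn(C5CCN(C(=O)CN(C)C)CC5)c4)cnc3N)nc3ccccc32)c1`, which keeps the rest of compound 2 and changes one group. On an aromatic nitrogen of a five-membered aromatic ring with 2 nitrogen, 1-(((dimethylamino)methyl)carbonyl)piperidin-4-yl comes in place of methyl: 1-(((dimethylamino)methyl)carbonyl)piperidin-4-yl in place of methyl on an aromatic nitrogen.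

Going by the values given here, no measured pair of compounds differs in just one place, so there is no direct precedent for the size of this change. The only exact figure to lean on is that of compound 1, at 35000 nM in this assay, and it offers a rough guide at best. A rise beyond the usual scatter is expected, and the estimated move is an at least 3.0-fold higher number from compound 2 to compound 3 (0.47 log units; beyond the scatter). That size is uncertain, since it starts from a limit rather than a number.

For compound 3 the expected value is 30000 nM, with an estimated range of 10000 nM to 90000 nM.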

Compound 3, solubility: 18000 nM
The estimate for compound 3 lay 1.7-fold (0.22 log units) above the measured number; low and high end bracket the measured number.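

In this assay, the aromatic nitrogen that held methyl in compound 2 also tolerates the much bulkier 1-(((dimethylamino)methyl)carbonyl)piperidin-4-yl, and with this group compound 3 gives an exact reading of 18000 nM. Replacing methyl with this group gives an at least 1.8-fold higher number from compound 2 to compound 3 (0.25 log units; that floor lies within the scatter), so the number goes up, but the part of the rise that can be vouched for does not clear the usual scatter. The entry for compound 2 is a limit of the assay and not a number, and the step rests on it: the limit of < 10000 nM in this assay, at which 1 of the 3 values shown sits.

The new group brings a piperidine ring, a carbonyl and a dimethylamino end all at once, so the compounds shown leave open which of these parts matters for this reading; a plain piperidin-4-yl or a chain ending in a carboxylic acid on the same nitrogen would begin to separate them. On these data alone, it also stays open whether an exact value for compound 2 would place the step clearly beyond the scatter or leave it within it.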